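Methyl in Place of Fluoro on the Aminophenyl Ring

A few compounds are considered here, and "the series" means these few. Any claim that something is new, unique, unknown or untested is made for them only; others in the source may bear on it.

Compound 3 `Fc1ccc(Nc2nc(SCc3ccc(C(F)(F)F)cc3)nc3ccccc23)cc1` gives 15000 nM in a functional assay on MDA-MB-231 cells (Homo sapiens) for cytotoxicity, read by MTT assay, with a stated time of 72 h; a lower number here means a stronger inhibitor, a higher number a weaker inhibitor. Compound 1 `CCCCCCCCNc1nc(SCc2ccc(C(F)(F)F)cc2)nc2ccccc12` gives 22300 nM in this assay. Compound 2 `COc1ccccc1Nc1nc(SCc2ccc(C(F)(F)F)cc2)nc2ccccc12` reaches only the limit of this assay, > 50000 nM. Compound 3 thus holds the lowest of the two numbers, though a 1.5-fold lower number from compound 1 to compound 3 (0.17 log units; within the scatter) is within the scatter, while an at least 3.3-fold lower number from compound 2 to compound 3 (0.52 log units; beyond the scatter) is beyond it. Compound 4 `Cc1ccc(Nc2nc(SCc3ccc(C(F)(F)F)cc3)nc3ccccc23)cc1` differs from compound 3 by methyl in place of fluoro on an aromatic carbon. The measured steps, an at least 2.2-fold higher number from compound 1 to compound 2 (0.35 log units; beyond the scatter) and an at least 3.3-fold lower number from compound 2 to compound 3 (0.52 log units; beyond the scatter), all exchange the whole group on the nitrogen; none alters a single substituent on an aromatic carbon, so they offer no direct guide. The author therefore expects for compound 4 a value of 15000 nM, with a range of 7000 nM to 35000 nM, which is expected to mean no change at the digits printed from compound 3 to compound 4 (within the scatter).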

Compound 4, half-maximal inhibitory concentration: > 50000 nM
Compound 4 ended at the assay's limit; the forecaster's own chance of this, stated with the estimate: 10%; middle value at least 3.3-fold (0.52 log units) from the limit.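

This position, para to a large group, responds to a single substituent: methyl in place of fluoro gives an at least 3.3-fold higher number from compound 3 to compound 4 (0.52 log units; beyond the scatter). The earlier steps shown here all exchanged the whole group on the nitrogen, whereas here one heavy atom replacing another is enough. The 4-methylphenyl group also separates from octyl, with an at least 2.2-fold higher number from compound 1 to compound 4 (0.35 log units; beyond the scatter), while compound 3 and compound 1 lie within the scatter of each other.

Going by these compounds, the step between compound 2 and compound 4 cannot be read because both values are limits: the limit of > 50000 nM in this assay, at which 2 of the 4 values shown sit. How a chloro group, a hydroxyl or an amine at this position would read stays open.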